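Swapping the benzyl substituent on the triazole carbamate

A few compounds are considered here, and "the series" means these few. Any claim that something is new, unique, unknown or untested is made for them only; others in the source may bear on it.

Going by the values given here, compound 3, `COc1ccc(Cn2cc(CSC(=S)N3CCN(C(=O)OCc4ccccc4)CC3)nn2)cc1`, is the only member of this set with a number in a functional assay on ECa-109 cells (Homo sapiens) for inhibition, read by MTT assay, with a stated time of 72 h; on this read-out lower numbers stand for stronger inhibition and higher numbers for weaker inhibition: compound 3 gives 58300 nM. Its two companions stop at the edge of the assay. Compound 1, `COc1ccc(-n2cc(CSC(=S)N3CCN(C(=O)OC(C)(C)C)CC3)nn2)cc1`, returns only a limit in this assay, > 128000 nM. Compound 2, `CC(C)(C)OC(=O)N1CCN(C(=S)SCc2cn(-c3ccccc3F)nn2)CC1`, likewise returns only a limit in this assay, > 128000 nM. Among the compounds with values here, the one measured step between these two, a step that the two limits leave unreadable from compound 1 to compound 2, is therefore a step whose size cannot be read, and the limit of > 128000 nM in this assay, at which 2 of the 3 values shown sit, is all the evidence that bears on it.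

Compound 4, `O=C(OCc1ccccc1)N1CCN(C(=S)SCc2cn(Cc3ccccc3F)nn2)CC1`, is the unmeasured partner of compound 3. The change is 2-fluorophenyl in place of 4-methoxyphenyl on a saturated chain carbon bound to an aromatic nitrogen. The same exchange of aryl groups, placed directly on the aromatic nitrogen rather than on the saturated chain carbon, is what separates compound 1 from compound 2, and that step is unreadable, so it gives neither a direction nor a size. With nothing readable to lean on, the expectation for compound 4 is a step near zero, within the usual scatter, and a real chance that the assay again returns only a limit. In this assay compound 4 is estimated at 70000 nM, with a range from 25000 nM to 200000 nM. The step from compound 3 to compound 4 is expected to be a 1.2-fold higher number from compound 3 to compound 4 (0.08 log units; within the scatter).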

Compound 4, half-maximal inhibitory concentration: 27000 nM
Compound 4: middle estimate off by 2.6-fold (0.41 log units), on the high side; low and high end bracket the measured number.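

In this assay, going by these compounds alone, the exchange of 4-methoxybenzyl for 2-fluorobenzyl yields the first readable step for this change of aryl group, a 2.2-fold lower number from compound 3 to compound 4 (0.33 log units; beyond the scatter), so the group on a saturated chain carbon bound to an aromatic nitrogen does move the read-out, though only modestly. The related exchange placed directly on the aromatic nitrogen could show no such thing, since compound 1 and compound 2 both return only a limit of the assay and the step between them cannot be read: the limit of > 128000 nM in this assay, at which 2 of the 4 values shown sit. This single pair gives a direction for this place alone, and because it swaps one whole group for another, it does not separate the loss of the methoxy group from the arrival of the fluorine.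

A plain benzyl or a 2-methoxybenzyl group at this place would help to tell those two contributions apart. Also open, on these data alone, is whether the same step would carry over to a tert-butyl carbamate in place of the benzyl carbamate of compound 4.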